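The source may report more compounds than this note shows. Statements on the series, on what has been measured and on what is new or still open speak of the compounds shown alone.

Compound 1, `Cc1cccc(/C=N/NC(=O)CSc2nnnn2-c2cccc3ccccc23)c1`, gives 269000 nM in an ADME assay on MT4 cells (Homo sapiens) for cytotoxicity, read by MTT assay; a higher number here means that more compound is tolerated, a lower number that less compound is tolerated.
Compound 2, `O=C(CSc1nnnn1-c1cccc2ccccc12)N/N=C/c1ccc(O)cc1`, gives in this assay only a limit, not a number: > 309000 nM.

Compound 2 therefore stands at the top of what has been seen, at a limit (the limit of > 309000 nM in this assay, at which 1 of the 2 values shown sits). Compound 3, `CN(C)c1ccc(/C=N/NC(=O)CSc2nnnn2-c2cccc3ccccc23)cc1`, carries dimethylamino in place of hydroxy on an aromatic carbon. Going by the values given here, the one measured step, an at least 1.1-fold higher number from compound 1 to compound 2 (0.06 log units; that floor lies within the scatter), also changed the substituent on that aromatic ring and stayed within the scatter. A step of similar size, not beyond the scatter, is expected here, in either direction. Compound 3 is expected to give 280000 nM, with a range from 150000 nM to 400000 nM. The expected step is an at least 1.1-fold lower number from compound 2 to compound 3 (0.04 log units; that floor lies within the scatter).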

Compound 3, half-maximal cytotoxic concentration: > 289000 nM
Compound 3 was reported as a limit (the forecaster's own chance of this, stated with the estimate: 45%); at least 1.0-fold (0.01 log units) between middle value and limit.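

Replacing 3-methylphenyl with 4-(dimethylamino)phenyl gives an at least 1.0-fold higher number from compound 1 to compound 3 (0.03 log units; that floor lies within the scatter) and so shows no measurable change in tolerance. Compound 3 carries no hydrogen-bond donor in its dimethylamino group, yet it also ends at a limit, so hydroxy is not needed on this aromatic carbon to reach one: the limit of > 289000 nM in this assay, at which 1 of the 3 values shown sits. The step between the two limits cannot be read.

On these data alone, how far compound 2 and compound 3 lie beyond their limits stays open. So does the effect of a carboxylic acid or a longer chain on this aromatic carbon.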